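Methylsulfanyl for Methoxy, Repeated on a Second Core

The source may report more compounds than this note shows. Statements on the series, on what has been measured and on what is new or still open speak of the compounds shown alone.

Compound 1, `CSc1ccc(CNc2nc(SC)nc3ncccc23)cc1`, gives 7030 nM in a functional assay on HT-29 cells (Homo sapiens) for cytotoxicity, read by MTT assay, with a stated time of 72 h; on this read-out lower numbers stand for stronger inhibition of growth and higher numbers for weaker inhibition of growth.
Compound 2, `COc1ccc(CNc2nc(SC)nc3ncccc23)cc1`, gives > 100000 nM in this assay, a limit of the assay and not a number.
Compound 3, `COc1ccc(CNc2nc(SC)nc3ccccc23)cc1`, gives > 100000 nM in this assay, again a limit of the assay and not a number.

Compound 1 and compound 2 share a core and differ only in one group on the outer ring: methylsulfanyl in place of methoxy on an aromatic carbon. This single exchange gives an at least 14-fold lower number from compound 2 to compound 1 (1.15 log units; beyond the scatter). The size of that step can only be given as a lower bound because of the limit of > 100000 nM in this assay, at which 2 of the 3 values shown sit. Compound 3 carries the same methoxy group as compound 2 on a different core; the difference between the two cores is not broken down here.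

Compound 4, `CSc1ccc(CNc2nc(SC)nc3ccccc23)cc1`, has not yet been measured in this assay. It stands to compound 3 as compound 1 stands to compound 2: methylsulfanyl in place of methoxy on an aromatic carbon, the same change in the same place on the outer ring. The expectation for compound 4 rests on compound 1 and on the step from compound 2 to compound 1, an at least 14-fold lower number from compound 2 to compound 1 (1.15 log units; beyond the scatter), with the caution that compound 3 itself shows only a limit. The step from compound 3 to compound 4 is expected to be about an at least 8.3-fold lower number from compound 3 to compound 4 (0.92 log units; beyond the scatter). Compound 4 is therefore estimated at 12000 nM, within a range from 2500 nM to 100000 nM.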

Compound 4, concentration for total growth inhibition: > 100000 nM
Compound 4: only a limit was reported; the forecaster's own chance of this, stated with the estimate: 35%; middle value at least 8.3-fold (0.92 log units) away from the limit.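

Within the data shown here, compound 3 and compound 4 both stop at the same limit of the assay and neither gives an actual number, so no step between them can be read, because both sit at one ceiling: the limit of > 100000 nM in this assay, at which 3 of the 4 values shown sit. The compounds shown leave open whether methylsulfanyl in place of methoxy changes growth inhibition at all on the core of compound 3, as it does on the core of compound 1.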